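The compounds below may be only part of what the source reports. "The series", "measured", "known", "first", "only" and "open" are said of these compounds alone.

Compound 1 `CCC(C)NC(=C\C(=O)/C=C/c1ccc(O)c(OC)c1)/C=C/c1ccc(O)c(OC)c1`: > 25000 nM
Compound 2 `COc1cc(/C=C/C(=O)/C=C(/C=C/c2ccc(OC(C)=O)c(OC)c2)NCC(C)C)ccc1OC(C)=O`: > 25000 nM

In a functional assay on Caco-2 cells (Homo sapiens) for inhibition, read by sulforhodamine B assay, with a stated time of 72 h (on this read-out higher numbers stand for weaker inhibition and lower numbers for stronger inhibition), compound 1 gives > 25000 nM, which is a limit and not a number. Compound 2 gives > 25000 nM, also a limit. Among the measured compounds shown here, the series therefore stands at the limit of > 25000 nM in this assay, at which 2 of the 2 values shown sit, and no measured step is available.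

Compound 3 `CCCCNC(=C\C(=O)/C=C/c1ccc(O)c(OC)c1)/C=C/c1ccc(O)c(OC)c1` differs from compound 1 as follows: butyl in place of sec-butyl on an amine nitrogen. This places butyl in place of sec-butyl on an amine nitrogen. In this assay no step beyond the usual scatter is expected, and no direction is favoured. The expected step is a number no higher from compound 1 to compound 3 (the limit leaves the size open). For compound 3 the estimated value is 25000 nM, with an expected range from 9000 nM to 50000 nM.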

Compound 3, half-maximal inhibitory concentration: 23800 nM
For compound 3 the middle estimate is 1.1-fold (0.02 log units) above the measured one; the range from low to high includes it.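

In this assay, among the compounds shown here, compound 3 gives 23800 nM, the only value so far that is a number and not a limit. Butyl in place of sec-butyl on the amine nitrogen gives an at least 1.0-fold lower number from compound 1 to compound 3 (0.02 log units; that floor lies within the scatter), so this change has no shown effect beyond the scatter, though the true size of the step stays unknown. The other values still mark the edge of what can be read: the limit of > 25000 nM in this assay, at which 2 of the 3 values shown sit.

Still open, on these data alone, is whether a longer chain, a cyclohexyl ring or a carboxylic acid on this amine nitrogen would shift the value beyond the scatter.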